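Isopropylamino for methyl on the pyrimidine of a diaryl urea

The source may hold more compounds than are shown below. What is called first, only, known or untested is meant among the compounds shown, and "the series" means these compounds.

Measured compounds:
- Compound 1 `CNc1cc(Oc2c(F)cc(NC(=O)Nc3cccc(C(F)(F)F)c3)cc2F)ncn1` gives 20 nM in an assay on isolated protein for inhibition of serine/threonine-protein kinase TNNI3K (Homo sapiens); a higher number here means a weaker inhibitor, a lower number a stronger inhibitor.
- Compound 2 `CNc1cc(Oc2c(C)cc(NC(=O)Nc3cccc(C(F)(F)F)c3)cc2C)ncn1` gives 25 nM in this assay.
- Compound 3 `Cc1cc(Oc2ccc(NC(=O)Nc3cccc(C(F)(F)F)c3)cc2)ncn1` gives 160 nM in this assay.

Compound 3 holds the highest of the three numbers, and so is the weakest inhibitor here; its gap to compound 2, the nearest of the other two, lies beyond the scatter, as does the wider gap to compound 1. Compound 3 also differs from those two in more than one place, so no single cause for its standing can be read from the numbers.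

Compound 4 `CC(C)Nc1cc(Oc2ccc(NC(=O)Nc3cccc(C(F)(F)F)c3)cc2)ncn1` is the next member and is not yet measured in this assay. Its difference from compound 3 is isopropylamino in place of methyl on an aromatic carbon, which cut one bond further out reads 6-methylpyrimidin-4-yl to 6-(isopropylamino)pyrimidin-4-yl. The two stronger compounds both carry an alkylamino group at this position of the shared core, but they also carry substituted phenyl rings, so the change is only loosely anchored. A step from compound 3 toward a lower number, of moderate size, is expected: a 3.2-fold lower number from compound 3 to compound 4 (0.51 log units; beyond the scatter). Compound 4 is estimated at 50 nM, within a range from 15 nM to 160 nM.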

Compound 4, half-maximal inhibitory concentration: 40 nM
The estimate for compound 4 lay 1.3-fold (0.10 log units) above the measured number; low and high end bracket the measured number.
By their numbers in this assay, from the lowest: compounds 1, 2 and 4 (each within the scatter of the next); then compound 3.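

Among these compounds, replacing methyl with isopropylamino at this position gives a 4.0-fold lower number from compound 3 to compound 4 (0.60 log units; beyond the scatter) in this assay, the first change that can be read at a single place, and the step lies beyond the scatter. Compound 4 reaches 40 nM without the fluoro or methyl substituents that compound 1 and compound 2 carry on their phenyl ring, so an alkylamino group at this position does not depend on those substituents for a number of this order. The change replaces one heavy atom with four and adds a hydrogen-bond donor and a hydrogen-bond acceptor, but no evidence at hand ties the step to any of these differences.

As far as these compounds go, compound 4 differs from compound 1 and compound 2 in more than one place, so those steps cannot be read, and what the phenyl substituents contribute on their own remains open. Also open, from the compounds shown here alone, is whether an unsubstituted amino, a methylamino or a methoxy group at this position would match isopropylamino, which would help separate the role of the nitrogen from that of the branched carbons.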